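Halogen swap on the aryl ring of compound 3

A few compounds are considered here, and "the series" means these few. Any claim that something is new, unique, unknown or untested is made for them only; others in the source may bear on it.

In a functional assay on MDA-MB-231 cells (Homo sapiens) for cytotoxicity, read by MTT assay, with a stated time of 48 h (a higher number here means a weaker inhibitor, a lower number a stronger inhibitor), the three measured compounds stand as follows:
- compound 1, `Cc1ccc2nc(Cl)c(/C=N/n3cc(-c4ccccc4)nc3N)cc2c1`, gives 48100 nM
- compound 2, `Cc1ccc(-c2cn(/N=C/c3cc4cc(C)ccc4nc3Cl)c(N)n2)cc1`, gives 22300 nM
- compound 3, `Cc1ccc2nc(Cl)c(/C=N/n3cc(-c4ccc(Cl)cc4)nc3N)cc2c1`, gives 35200 nM

Compound 3 sits in the middle of the three numbers in this assay. Its nearest neighbour is compound 1, the step of a 1.4-fold lower number from compound 1 to compound 3 (0.14 log units; within the scatter) lying within the scatter; its step to compound 2, a 1.6-fold higher number from compound 2 to compound 3 (0.20 log units; within the scatter), also lies within the scatter. For the measured compounds named here, only the step of a 2.2-fold lower number from compound 1 to compound 2 (0.33 log units; beyond the scatter) stands beyond the scatter, and that one is modest.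

Compound 4, `Cc1ccc2nc(Cl)c(/C=N/n3cc(-c4ccc(Br)cc4)nc3N)cc2c1`, differs from compound 3 by bromo in place of chloro on an aromatic carbon. The measured steps that bear on this change are those at the same aromatic carbon: a 1.4-fold lower number from compound 1 to compound 3 (0.14 log units; within the scatter) and a 1.6-fold higher number from compound 2 to compound 3 (0.20 log units; within the scatter), both within the scatter. Changing the group at this carbon has so far moved this assay little. The step of a 1.2-fold lower number from compound 3 to compound 4 (0.07 log units; within the scatter) is therefore expected to be small, with no clear direction beyond the scatter. Compound 4 is estimated at 30000 nM, with a range from 15000 nM to 60000 nM.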

Compound 4, half-maximal inhibitory concentration: 38200 nM
Compound 4: the middle estimate sits 1.3-fold (0.10 log units) below what was measured, within the range that was stated.
By their numbers in this assay, from the lowest: compounds 2, 3, 4 and 1 (each within the scatter of the next, the first and the last beyond it).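

In this assay the step of a 1.1-fold higher number from compound 3 to compound 4 (0.04 log units; within the scatter) shows that bromo in place of chloro on this aromatic carbon, para to a large group, does not separate the two halogens. The steps of a 1.3-fold lower number from compound 1 to compound 4 (0.10 log units; within the scatter) and a 1.7-fold higher number from compound 2 to compound 4 (0.23 log units; within the scatter) place compound 4 within the scatter of both the hydrogen and the methyl compounds, so that among these four groups only a 2.2-fold lower number from compound 1 to compound 2 (0.33 log units; beyond the scatter) stands beyond the scatter. No measurement is given here that would explain this narrow spread.

The compounds shown carry only hydrogen, methyl, chloro and bromo at this carbon, so whether an amine or a carboxylic acid there would move the number beyond the scatter stays open. On these data alone, whether changes elsewhere on the shared core would do so also stays open.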